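Cyclopentyl in Place of Allyl: An Expected Gain

A few compounds are considered here, and "the series" means these few. Any claim that something is new, unique, unknown or untested is made for them only; others in the source may bear on it.

Compound 3 `C=CCC(O/N=C(\C)C(=O)O)c1ccc(OCc2ccc3ccccc3n2)cc1` stands at the high end of the three numbers at hand: in a functional assay for inhibition of Polyunsaturated fatty acid 5-lipoxygenase (Homo sapiens) (on this read-out lower numbers stand for stronger inhibition and higher numbers for weaker inhibition), compound 3 gives 142 nM. Compound 1 `CC/C(=N\OC(c1ccc(OCc2ccc3ccccc3n2)cc1)C1CCCCC1)C(=O)O` gives 30 nM in this assay, and compound 2 `O=C(O)c1ccc(/C=N/OC(c2ccc(OCc3ccc4ccccc4n3)cc2)C2CCCCC2)cc1` gives 31 nM; each of these sits apart from compound 3 by a gap beyond the scatter. Among the measured compounds shown here, the only step recorded between measured compounds, a 1.0-fold higher number from compound 1 to compound 2 (0.01 log units; within the scatter), concerns a different part of the molecule and is within the scatter, so it says little about the change at issue here.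

Compound 4 `C/C(=N\OC(c1ccc(OCc2ccc3ccccc3n2)cc1)C1CCCC1)C(=O)O` has not been measured. It differs from compound 3 by cyclopentyl in place of allyl on a saturated chain carbon bound to an aromatic carbon and an oxygen on an unsaturated carbon. For the measured compounds named here, no measured pair isolates this change, so the expectation rests on a looser comparison: compound 1 and compound 2 both differ from compound 3 at this same saturated chain carbon, among other places, and both give markedly lower numbers in this assay than compound 3. On that basis the step from compound 3 to compound 4 is expected to be downward and beyond the scatter, about a 3.2-fold lower number from compound 3 to compound 4 (0.50 log units; beyond the scatter). Compound 4 is therefore estimated at 45 nM in this assay, with a range from 20 nM to 110 nM.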

Compound 4, half-maximal inhibitory concentration: 16 nM
For compound 4 the middle estimate is 2.8-fold (0.45 log units) above the measured one; the whole stated range lies above it.
By their numbers in this assay, from the lowest: compounds 4, 1 and 2 (each within the scatter of the next); then compound 3.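

In this assay, cyclopentyl in place of allyl on a saturated chain carbon bound to an aromatic carbon and an oxygen on an unsaturated carbon gives an 8.9-fold lower number from compound 3 to compound 4 (0.95 log units; beyond the scatter) with the rest of the molecule unchanged. Compound 1 and compound 2 each differ from compound 3 in more than one place, whereas this pair ties a change beyond the scatter to this position alone and shows that the group held there matters on this read-out. The change swaps an open chain carrying a double bond for a five-membered non-aromatic ring of carbon only, and nothing at hand explains why the number falls.

The compounds shown do not separate the gain from the ring, from the loss of the double bond or from the larger count of heavy atoms, and a plain propyl group at this carbon would help to tell these apart. From the compounds shown here alone, it also remains open how far the trend runs across ring sizes on this otherwise unchanged frame, from cyclobutyl upward, and whether an amine carried on the ring would be tolerated at this position.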